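Sulfonamide series against mitochondrial malate dehydrogenase: a limit-bound step

The compounds below may be only part of what the source reports. "The series", "measured", "known", "first", "only" and "open" are said of these compounds alone.

Working notes. Compound 1 `O=S(=O)(Nc1ccc(-c2nc3ccccc3o2)cc1)c1cccc(Cl)c1` carries a 3-chlorophenyl on the sulfonyl sulfur. In an assay on isolated protein for inhibition of malate dehydrogenase, mitochondrial (Sus scrofa), with stated times of 45 min and 30 min (a lower number here means a stronger inhibitor, a higher number a weaker inhibitor), compound 1 gives > 63000 nM, which is a limit of the assay and not a number. Compound 3 `O=S(=O)(Nc1ccc(-c2nc3ccccc3o2)cc1)c1cccc(C(F)(F)F)c1` differs from compound 1 by trifluoromethyl in place of chloro on an aromatic carbon. In this assay compound 3 gives > 63000 nM, again a limit. The step that the two limits leave unreadable from compound 1 to compound 3 therefore cannot be read. Compound 2 `COc1ccc(Cl)cc1S(=O)(=O)Nc1ccc2oc(-c3ccccc3)nc2c1` is the third member of the set. In this assay compound 2 gives > 63000 nM, also a limit. the limit of > 63000 nM in this assay, at which 3 of the 3 values shown sit, sums up the position: every measured value here is a limit, and compound 1 stands at it, with nothing to place it relative to compounds 2 and 3.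

Compound 4 `O=S(=O)(Nc1ccc(-c2nc3ccccc3o2)cc1)c1ccc(F)cc1` is not yet measured. It differs from compound 1 by 4-fluorophenyl in place of 3-chlorophenyl on a sulfonyl sulfur. For the measured compounds named here, the only measured step bearing on it is a step that the two limits leave unreadable from compound 1 to compound 3, unreadable, so no direction can be expected beyond the scatter. In this assay the expected step is a step that the limit leaves unreadable from compound 1 to compound 4. For compound 4 in this assay the estimate is 100000 nM, with a range from 30000 nM to 400000 nM, and the assay is most likely to report only a limit once more.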

Compound 4, half-maximal inhibitory concentration: > 63000 nM
Compound 4: a limit, no number (the forecaster's own chance of this, stated with the estimate: 85%); the middle value does not contradict the limit.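

Compound 4 gives > 63000 nM in this assay, which is a limit and not a number. For the compounds shown here, compound 1 also stands at a limit, so no step from compound 1 to compound 4 can be read. The compounds shown leave open whether any member of this series gives a measurable inhibition, and how the groups on the sulfonyl sulfur would rank: the limit of > 63000 nM in this assay, at which 4 of the 4 values shown sit.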